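The source may hold more compounds than are shown below. What is called first, only, known or untested is meant among the compounds shown, and "the series" means these compounds.

Measured in a functional assay on SW480 cells (Homo sapiens) for antiproliferative activity, read by MTT assay, with a stated time of 48 h; on this read-out higher numbers stand for weaker inhibition and lower numbers for stronger inhibition:
- compound 1 `CCCCCCCCC(CCO)n1cnc2c(NC)ncnc21`: 3770 nM
- compound 2 `CCCCCCCCCC(CCO)n1cnc2c(NC)ncnc21`: 4450 nM

Among the compounds with values here, only two numbers exist so far, and they lie within the scatter of each other, so compound 2 cannot be ranked against compound 1. The two compounds share a core and a hydroxyl-ended side chain, and they differ only in how far that chain runs.

Compound 3 `CCCCCCCCCCCC(CCO)n1cnc2c(NC)ncnc21` takes the same chain further. Its difference from compound 2 is ethyl in place of hydrogen on a saturated chain carbon, ten or more bonds along the chain from an aromatic nitrogen.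

Within the data shown here, one measured step bears on this change, a methyl in place of hydrogen on the same chain: a 1.2-fold higher number from compound 1 to compound 2 (0.07 log units; within the scatter). That step did not leave the scatter. The new change adds more than that one did, and a single pair is thin evidence, so the range has to stay wide. Even so, no step beyond the scatter is expected in this assay.

The expected step is a 1.1-fold higher number from compound 2 to compound 3 (0.03 log units; within the scatter).

For compound 3 the estimated value is 4800 nM, with an expected range from 2200 nM to 10500 nM.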

Compound 3, half-maximal inhibitory concentration: 12800 nM
For compound 3 the middle estimate is 2.7-fold (0.43 log units) below the measured one; the measured number lies above the stated range.
By their numbers in this assay, from the lowest: compounds 1 and 2 (each within the scatter of the next); then compound 3.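

In this assay, this position turns out to respond to added chain length: ethyl in place of hydrogen on a saturated chain carbon, ten or more bonds along the chain from an aromatic nitrogen, gives a 2.9-fold higher number from compound 2 to compound 3 (0.46 log units; beyond the scatter). The smaller methyl change gave only a 1.2-fold higher number from compound 1 to compound 2 (0.07 log units; within the scatter), so it could not show whether the chain length mattered at all, whereas the larger change shows a real loss of inhibition. The full change of propyl in place of hydrogen, which gives a 3.4-fold higher number from compound 1 to compound 3 (0.53 log units; beyond the scatter), points the same way, though no measurement here explains why the longer chain inhibits less.

From the compounds shown here alone, these three compounds cover only a short stretch of chain lengths, so it remains open whether a longer chain would raise the number further or a shorter chain would lower it. Going by these compounds, it also remains open how this position would respond to something other than plain carbon chain, such as an amine or a carboxylic acid on the chain.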